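This account rests on a few compounds, and the source may have more. Where it says the series, first, only, none or still open, it means among the compounds named here.

In a functional assay on HT-29 cells (Homo sapiens) for inhibition (a higher number here means a weaker inhibitor, a lower number a stronger inhibitor), compound 1 `COc1ccc(/C=C/c2ccc3ccccc3c2)cc1` gives > 5000 nM, which is a limit and not a number. Compound 2 `COc1ccc(/C=C/c2ccc3ccccc3c2)cc1[N+](=O)[O-]` also gives only a limit, > 5000 nM. As far as these compounds go, compound 3 `COc1ccc(/C=C/c2ccc3ccccc3c2)cc1N` gives a limit too, > 5000 nM, so its true position is unknown. The record so far is the limit of > 5000 nM in this assay, at which 3 of the 3 values shown sit.

Compound 4 `COc1c(N)cc(/C=C/c2ccc3ccccc3c2)cc1N` differs from compound 3 by one change, amino in place of hydrogen on an aromatic carbon, ortho to a methoxy group and meta to an amino group. The nearest measured precedent is a step that the two limits leave unreadable from compound 1 to compound 3, which is the same kind of exchange. The other two, a step that the two limits leave unreadable from compound 1 to compound 2 and a step that the two limits leave unreadable from compound 2 to compound 3, give no size either. Within the data shown here, no measured step therefore offers a size or a direction, and the most likely outcome is another reading at the limit. The expected change in this assay is a step that the limit leaves unreadable from compound 3 to compound 4, with no firm direction behind it. For compound 4 the estimated value is 6000 nM, with an expected range of 1500 nM to 20000 nM.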

Compound 4, half-maximal inhibitory concentration: > 5000 nM
Compound 4 gave a limit, no number; the forecaster's own chance of this, stated with the estimate: 75%; the middle value lies beyond the limit too.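

In this assay compound 4 gives > 5000 nM, a limit and not a number, so the step from compound 3 to compound 4 cannot be read. How far any of the compounds shown truly lies past that limit, and whether any amino exchange alters inhibition, stays open because all share it: the limit of > 5000 nM in this assay, at which 4 of the 4 values shown sit.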